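This account rests on a few compounds, and the source may have more. Where it says the series, first, only, none or still open, it means among the compounds named here.

In an in vitro functional assay on RBL cells for antagonist activity at C-C chemokine receptor type 8 (Homo sapiens), read by FLIPR and calcium flux (a higher number here means a weaker inhibitor, a lower number a stronger inhibitor), compound 1 `COc1ccc2nccc(C3CN(C4CCN(Cc5cc6ccccc6[nH]5)CC4)C(=O)O3)c2c1` gives 25.1 nM. Going by the values given here, compound 3 `O=C1OC(c2ccnc3ccccc23)CN1C1CCN(Cc2cc3ccccc3[nH]2)CC1`, which keeps the shared core but carries hydrogen in place of methoxy on an aromatic carbon, gives 1000 nM in this assay; the step of a 40-fold higher number from compound 1 to compound 3 (1.60 log units; beyond the scatter) is the only single change with two numbers here. Compound 2 `COc1ccc2nccc(C3CN(CC4CCN(Cc5cc6ccccc6[nH]5)CC4)C(=O)O3)c2c1` reaches only the limit < 50200 nM in this assay, as noted in the limit of < 50200 nM in this assay, at which 1 of the 3 values shown sits. Among the two numbers shown, compound 3 stands at the higher one, the weaker end.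

Compound 4 `O=C1OC(c2cnc3ccccc3c2)CN1C1CCN(Cc2cc3ccccc3[nH]2)CC1` differs from compound 3 by quinolin-3-yl in place of quinolin-4-yl on a saturated ring carbon. Among the compounds with values here, none of the measured steps moves the quinoline nitrogen, so no step bears directly on this change; the change from compound 1 to compound 3 concerns a different part of the molecule. With no guide, the expectation is a moderate rise in number for compound 4, and the step is estimated as a 3.0-fold higher number from compound 3 to compound 4 (0.48 log units; beyond the scatter) in this assay. Compound 4 is therefore expected to give about 3000 nM in this assay, within a range from 500 nM to 30000 nM.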

Compound 4, half-maximal inhibitory concentration: < 50200 nM
Compound 4: a limit, no number; the forecaster's own chance of this, stated with the estimate: 20%; the middle value is on the limit's open side.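

Compound 4 gives a limit rather than a number, so the step from compound 3 to compound 4 cannot be read: the limit of < 50200 nM in this assay, at which 2 of the 4 values shown sit.

The compounds shown leave open how large a change, if any, quinolin-3-yl in place of quinolin-4-yl brings in this assay.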